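Cyclopentylmethyl in place of cyclopentyl: working notes

The source may hold more compounds than are shown below. What is called first, only, known or untested is meant among the compounds shown, and "the series" means these compounds.

Compound 1 `O=c1c(S(=O)(=O)c2ccc(F)cc2F)cc2cnc(Nc3ccc4[nH]ccc4c3)nc2n1C1CCCC1`: 5000 nM
Compound 2 `Cc1ccc(S(=O)(=O)c2cc3cnc(Nc4ccc5[nH]ccc5c4)nc3n(C)c2=O)cc1`: 750 nM

Both values come from a functional assay on DU-145 cells (Homo sapiens) for inhibition, read by trypan blue exclusion, with a stated time of 72 h; on this read-out higher numbers stand for weaker inhibition and lower numbers for stronger inhibition. Compound 1 stands highest of the two at 5000 nM, which makes it the weaker inhibitor, and compound 2 lies lower at 750 nM, a gap beyond the scatter. These two compounds differ in more than one place, so their gap cannot be assigned to any single change.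

The next entry is compound 3 `O=c1c(S(=O)(=O)c2ccc(F)cc2F)cc2cnc(Nc3ccc4[nH]ccc4c3)nc2n1CC1CCCC1`, which differs from compound 1 as follows: cyclopentylmethyl in place of cyclopentyl on an aromatic nitrogen. In words, this is cyclopentylmethyl in place of cyclopentyl on an aromatic nitrogen, with the (2,4-difluorophenyl)sulfonyl group and the shared core left unchanged.

Within the data shown here, no measured pair shows a step at one place in this assay, so the only anchor is compound 1 at 5000 nM. No step beyond the scatter is expected in either direction, and the range is kept wide. The expected step is a 1.1-fold lower number from compound 1 to compound 3 (0.05 log units; within the scatter). The estimate for compound 3 is 4500 nM, with an expected range of 1500 nM to 12000 nM.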

Compound 3, half-maximal inhibitory concentration: 10000 nM
Beside the measured number, compound 3's estimate is 2.2-fold (0.35 log units) below it, within the range that was stated.
By their numbers in this assay, from the lowest: compound 2; then compounds 1 and 3 (each within the scatter of the next).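

In this assay, among these compounds, the swap of cyclopentyl for cyclopentylmethyl on the aromatic nitrogen gives a 2.0-fold higher number from compound 1 to compound 3 (0.30 log units; within the scatter) and this is the first step that can be read at a single place. With the (2,4-difluorophenyl)sulfonyl group and the shared core held fixed, this step stays within the scatter, so the read-out does not separate the ring attached directly to the nitrogen from the same ring attached through one added carbon. No measurement shown here bears on why the step has this size.

Compound 2 differs from both compounds in more than one place, so it does not show how the substituent on this nitrogen acts on its own with the (2,4-difluorophenyl)sulfonyl group in place. Going by these compounds, whether a larger change at this position, such as a cyclohexyl ring, a longer chain such as n-butyl or a chain ending in an amine, would move the number beyond the scatter remains open.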